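Working notes on the aryl change from compound 3 to compound 4

The source may report more compounds than this note shows. Statements on the series, on what has been measured and on what is new or still open speak of the compounds shown alone.

Measured compounds in a functional assay on A549 cells (Homo sapiens) for cytotoxicity, read by MTT assay, with a stated time of 48 h; on this read-out higher numbers stand for weaker inhibition and lower numbers for stronger inhibition:
compound 1 `CCOC(=O)c1c(-c2c(Cl)c3cc(C)ccc3oc2=O)nn(-c2ccccc2)c1C(=O)OCC` gives 108000 nM
compound 2 `CCOC(=O)c1c(-c2c(Cl)c3cc(C)ccc3oc2=O)nn(-c2cccc(C)c2)c1C(=O)OCC` gives 115000 nM
compound 3 `CCOC(=O)c1c(-c2cc3ccccc3oc2=O)nn(-c2ccc(C)c(C)c2)c1C(=O)OCC` gives 52000 nM

Compound 3 holds the lowest number of the three; compounds 1 and 2 both stand beyond the scatter above it. Compound 4 `CCOC(=O)c1c(-c2cc3ccccc3oc2=O)nn(-c2ccc(Cl)cc2)c1C(=O)OCC` differs from compound 3 in one place: 4-chlorophenyl in place of 3,4-dimethylphenyl on an aromatic nitrogen. Among the measured compounds shown here, the only measured step that touches the aryl group on the ring nitrogen is a 1.1-fold higher number from compound 1 to compound 2 (0.03 log units; within the scatter), and it lies within the scatter. For the measured compounds named here, no measured pair swaps an aromatic methyl for chlorine, and compounds 1 and 2 differ from compound 3 at the core as well, so they give no clean reading on the aryl group alone. Compound 4 is therefore expected to show a step of a 1.1-fold higher number from compound 3 to compound 4 (0.02 log units; within the scatter), not beyond the scatter. The estimate for compound 4 is 55000 nM, with a range of 25000 nM to 120000 nM.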

Compound 4, half-maximal inhibitory concentration: 35000 nM
Compound 4: middle estimate off by 1.6-fold (0.20 log units), on the high side; low and high end bracket the measured number.
By their numbers in this assay, from the lowest: compounds 4 and 3 (each within the scatter of the next); then compounds 1 and 2 (each within the scatter of the next).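

In this assay, the aryl change on the aromatic nitrogen, read on the core shared by compounds 3 and 4, gives a 1.5-fold lower number from compound 3 to compound 4 (0.17 log units; within the scatter), so this assay does not separate 4-chlorophenyl from 3,4-dimethylphenyl. With a 1.1-fold higher number from compound 1 to compound 2 (0.03 log units; within the scatter) on a different core, two aryl changes at this position now stand within the scatter. No supporting measurement bears on this result.

Still open, as far as these compounds go, is whether an amine or a carboxylic acid on this phenyl ring would move the number beyond the scatter. The same holds for a longer chain on the aromatic nitrogen in place of the phenyl ring.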